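Benzoyl on the aromatic nitrogen of compound 2

This account rests on a few compounds, and the source may have more. Where it says the series, first, only, none or still open, it means among the compounds named here.

In an ADME assay on CCRF-CEM cells (Homo sapiens) for cytotoxicity, with a stated time of 3 days (a lower number here means that less compound is tolerated, a higher number that more compound is tolerated), compound 2 (`Cc1cc(=O)[nH]c(=O)n1C1C=CC(OC(=O)c2ccccc2)C1`) gives > 250000 nM as a limit and not a number. Compound 3 (`O=c1ccn(C2C=CC(O)C2)c(=O)n1Cc1ccccc1`) gives > 250000 nM which is also a limit. Compound 1 (`O=C(OC1C=CC(n2ccc(=O)n(Cc3ccccc3)c2=O)C1)c1ccccc1`) gives > 25000 nM which is a limit as well. The series therefore offers no numerical read-out, and compound 2 can be placed only by its limit.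

The change to compound 4 (`Cc1cc(=O)n(C(=O)c2ccccc2)c(=O)n1C1C=CC(OC(=O)c2ccccc2)C1`) is benzoyl in place of hydrogen on an aromatic nitrogen and in words it is benzoyl in place of hydrogen on an aromatic nitrogen, para to a methyl group.

Going by the values given here, only one measured step comes close to this change: a step that the two limits leave unreadable from compound 1 to compound 3 and it concerns a benzoyl on an oxygen on a saturated carbon, not on an aromatic nitrogen. It supplies neither a size nor a firm direction to carry over.

With that step unreadable, another limit is the most likely report for compound 4 in this assay and any number would be expected to fall on the lower side, with less compound tolerated. The expected change is an at least 2.5-fold lower number from compound 2 to compound 4 (0.39 log units; beyond the scatter) and this estimate has no readable step behind its size. Compound 4 is estimated at 100000 nM with an expected range from 25000 nM to 250000 nM in this working estimate.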

Compound 4, half-maximal cytotoxic concentration: 191000 nM
For compound 4 the middle estimate is 1.9-fold (0.28 log units) below the measured one; measured number inside the range.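

In this assay, going by these compounds alone, compound 4 gives 191000 nM, the first actual number, so the position para to a methyl group, on the aromatic nitrogen, yields a readable value with a benzoyl in place of hydrogen. Compound 2 gives > 250000 nM, which is a limit of the assay and not a number. Within the data shown here, the change therefore reads as an at least 1.3-fold lower number from compound 2 to compound 4 (0.11 log units; that floor lies within the scatter), which fixes the direction as lower but gives only a floor for the size, and the earlier compounds offered neither.

The true size of this step stays open, and the one earlier step, on the oxygen on a saturated carbon, cannot be read, because the values behind them are limits: the limit of > 250000 nM in this assay, at which 2 of the 4 values shown sit.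
Also open, as far as these compounds go, is how the number in this assay responds to other groups on this aromatic nitrogen, such as acetyl, a longer alkyl chain or a chain ending in an amine or a carboxylic acid, and whether the benzoyl on the oxygen matters once the nitrogen carries a benzoyl.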